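The compounds below may be only part of what the source reports. "The series", "measured", "known", "first", "only" and "open" are said of these compounds alone.

Series notes. Compound 1 `COc1ccc(S(=O)(=O)c2nc3ccccc3nc2N2CCCC2)cc1` is the reference; in a functional assay on KB cells (Homo sapiens) for cytotoxicity, read by MTT assay, with a stated time of 72 h (a higher number here means a weaker inhibitor, a lower number a stronger inhibitor), compound 1 gives > 50000 nM, which is a limit of the assay and not a number (the limit of > 50000 nM in this assay, at which 1 of the 3 values shown sits). Compound 2 `O=S(=O)(c1ccc(F)cc1)c1nc2ccccc2nc1N1CCCC1` carries fluoro in place of methoxy on an aromatic carbon; in this assay compound 2 gives 30100 nM, a step of an at least 1.6-fold lower number from compound 1 to compound 2 (0.22 log units; that floor lies within the scatter). Compound 3 `COc1ccc(S(=O)(=O)c2nc3ccccc3nc2N2CCC(O)CC2)cc1` differs from compound 1 in the core (4-hydroxypiperidin-1-yl in place of pyrrolidin-1-yl on an aromatic carbon); in this assay compound 3 gives 8060 nM, a step of an at least 6.2-fold lower number from compound 1 to compound 3 (0.79 log units; beyond the scatter). Compound 4 `O=S(=O)(c1ccc(F)cc1)c1nc2ccccc2nc1N1CCC(O)CC1` is not yet measured; it repeats the change made in compound 2, now on the core of compound 3, at the same place (fluoro in place of methoxy on an aromatic carbon). Set beside the earlier step, the step in this assay from compound 3 to compound 4 is expected to be a 1.6-fold lower number from compound 3 to compound 4 (0.21 log units; within the scatter), resting on the measured step of an at least 1.6-fold lower number from compound 1 to compound 2 (0.22 log units; that floor lies within the scatter). Compound 4 is expected to give 5000 nM, between 2000 nM and 15000 nM.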

Compound 4, half-maximal inhibitory concentration: 9580 nM
Beside the measured number, compound 4's estimate is 1.9-fold (0.28 log units) below it; low and high end bracket the measured number.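

In this assay, fluoro in place of methoxy gives a 1.2-fold higher number from compound 3 to compound 4 (0.08 log units; within the scatter), and whether this matches the same change on the core of compound 1 stays unresolved: the same change on two cores in this assay, an at least 1.6-fold lower number (0.22 log units; that floor lies within the scatter) from compound 1 to compound 2 and a 1.2-fold higher number (0.08 log units; within the scatter) from compound 3 to compound 4; the limit leaves it open whether they differ. 4-Hydroxypiperidin-1-yl in place of pyrrolidin-1-yl gives a 3.1-fold lower number from compound 2 to compound 4 (0.50 log units; beyond the scatter), which runs the same way as on the methoxy side, but the two sizes cannot be compared: the same change on two cores in this assay, an at least 6.2-fold lower number (0.79 log units; beyond the scatter) from compound 1 to compound 3 and a 3.1-fold lower number (0.50 log units; beyond the scatter) from compound 2 to compound 4; the limit leaves it open whether they differ. Compound 1 stands at > 50000 nM, a limit of the assay and not a number, so neither change has a measured size on both cores.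

Still open, on these data alone, is how an amine or a carboxylic acid would read on the aromatic carbon para to a large group. Also open, as far as these compounds go, is how a morpholine would read in place of 4-hydroxypiperidin-1-yl.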